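The source may hold more compounds than are shown below. What is called first, only, known or untested is meant among the compounds shown, and "the series" means these compounds.

Among the compounds with values here, in a functional assay on MCF7 cells (Homo sapiens) for antiproliferative activity, read by CellTiter-Glo, with a stated time of 5 days (on this read-out higher numbers stand for weaker inhibition and lower numbers for stronger inhibition), compound 3 (`CC1=C(c2ccccc2)C(c2ccc(OC[C@H](C)N3CC[C@@H](C)C3)cc2)Oc2ccc(O)cc21`) gives 0.4 nM, the lowest of the three numbers so far. Compound 2 (`CC1=C(c2ccc(C#N)cc2)C(c2ccc(OC[C@H](C)N3CC[C@@H](C)C3)cc2)Oc2ccc(O)cc21`) gives 10 nM, and compound 1 (`CC1=C(c2ccc(S(C)(=O)=O)cc2)C(c2ccc(OC[C@H](C)N3CC[C@@H](C)C3)cc2)Oc2ccc(O)cc21`) gives 27 nM.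

Compound 4 (`CC1=C(c2cccc(C#N)c2)C(c2ccc(OC[C@H](C)N3CC[C@@H](C)C3)cc2)Oc2ccc(O)cc21`) changes phenyl to 3-cyanophenyl: cyano in place of hydrogen on an aromatic carbon, meta to a large group (cyano in place of hydrogen on an aromatic carbon).

Within the data shown here, two measured steps bear on this change. The closer is a 25-fold lower number from compound 2 to compound 3 (1.40 log units; beyond the scatter), which is large and, read in reverse, also has a cyano entering that phenyl. The second is a 68-fold lower number from compound 1 to compound 3 (1.83 log units; beyond the scatter), also large, where methylsulfonyl is the group replaced by hydrogen. In all three compounds, the unsubstituted phenyl has the lowest number, and none goes against this. a 2.7-fold lower number from compound 1 to compound 2 (0.43 log units; beyond the scatter) is only modest, but it compares two substituents and says less about adding one.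

Among the measured compounds shown here, the group in compound 2 is not the 3-cyanophenyl of compound 4, and no measured compound carries that group, so the transfer is only partial. A clear rise is still expected, probably somewhat smaller than the compound 2 step. The expected change is a 10-fold higher number from compound 3 to compound 4 (1.00 log units; beyond the scatter), towards weaker inhibition. For compound 4 the estimated value is 4 nM, with an expected range of 0.8 nM to 15 nM.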

Compound 4, half-maximal inhibitory concentration: 2.6 nM
Compound 4: the middle estimate sits 1.5-fold (0.19 log units) above what was measured; low and high end bracket the measured number.
By their numbers in this assay, from the lowest: compound 3; then compound 4; then compound 2; then compound 1.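

In this assay, a cyano group on the phenyl ring, meta to a large group, now has a direct measure of its own: a 6.5-fold higher number from compound 3 to compound 4 (0.81 log units; beyond the scatter), so the unsubstituted phenyl still gives the lowest number of the four compounds, and none goes against this. Where the cyano sits also counts, which the earlier compounds could not show, since moving from the 4-cyanophenyl to the 3-cyanophenyl gives a 3.8-fold lower number from compound 2 to compound 4 (0.59 log units; beyond the scatter), a step beyond the scatter that keeps the same group and changes only its place on the ring. The cost of a substituent on this ring therefore depends on more than its presence, and the 3-cyanophenyl also stands well clear of the 4-(methylsulfonyl)phenyl, with a 10-fold lower number from compound 1 to compound 4 (1.02 log units; beyond the scatter).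

Nothing available explains why the two cyano placements differ. The compounds shown leave open whether a smaller group such as fluorine or methyl, or a hydroxyl or an amine, on this ring would come closer to the unsubstituted phenyl, and how methylsulfonyl would behave in the meta place that the 3-cyanophenyl occupies.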